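The source may report more compounds than this note shows. Statements on the series, on what has been measured and on what is new or still open speak of the compounds shown alone.

Of the compounds shown here, two in the same series have been measured so far. In a functional assay on OVCAR-4 cells (Homo sapiens) for inhibition, read by sulforhodamine B assay, with a stated time of 48 h (on this read-out higher numbers stand for weaker inhibition of growth and lower numbers for stronger inhibition of growth), compound 1 `O=C(Nc1cccc(-n2cc(-c3ccncc3)c(-c3ccc(Cl)c(O)c3)n2)c1)Nc1cccc(C(F)(F)F)c1` gives 3180 nM, and compound 2 `COc1cc(-c2nn(-c3cccc(NC(=O)Nc4ccc(Cl)c(Cl)c4)c3)cc2-c2ccncc2)ccc1Cl` gives 1290 nM, the lower of the two numbers and far enough from compound 1 to lie beyond the usual scatter. Compound 3 `O=C(Nc1cccc(-n2cc(-c3ccncc3)c(-c3ccc(Cl)c(O)c3)n2)c1)Nc1ccc(Cl)c(Cl)c1` has not yet been tested in this assay. It differs from compound 2 by a single change: hydrogen in place of methyl on an oxygen on an aromatic ring. Among the measured compounds shown here, no measured pair shows this change on its own, so its effect is open; a step of modest size in either direction is expected, with little change as a likely outcome. Compound 3 is therefore expected to give 1800 nM, within a range from 700 nM to 5000 nM, a step from compound 2 of a 1.4-fold higher number from compound 2 to compound 3 (0.14 log units; within the scatter).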

Compound 3, concentration for 50% growth inhibition: 1690 nM
Compound 3: the middle estimate sits 1.1-fold (0.03 log units) above what was measured; measured number inside the range.
By their numbers in this assay, from the lowest: compounds 2, 3 and 1 (each within the scatter of the next, the first and the last beyond it).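

In this assay, hydroxy in place of methoxy on the 4-chloro-3-methoxyphenyl group gives a 1.3-fold higher number from compound 2 to compound 3 (0.12 log units; within the scatter), so this direct comparison shows that the change makes no difference beyond the scatter at this position. Compound 3 also allows a one-place comparison at the other end of the molecule: 3,4-dichlorophenyl in place of 3-(trifluoromethyl)phenyl gives a 1.9-fold lower number from compound 1 to compound 3 (0.27 log units; within the scatter), again within the scatter. From the compounds shown here alone, whether an amine or a longer chain such as an ethoxy group on this ring would shift the number remains open. No available evidence explains either small step.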